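Thiazole for Pyrimidine on the Sulfonamide Nitrogen

The source may report more compounds than this note shows. Statements on the series, on what has been measured and on what is new or still open speak of the compounds shown alone.

Compound 2 `O=S(=O)(Nc1ncccn1)c1ccc2c(c1)OCC[C@@H]2c1ccc(C(F)(F)F)cc1-c1ccc(F)nc1` was tested in an ADME assay on the whole organism (Mus musculus, strain BALB/c) for pharmacokinetics, read by LC-MS, with a stated time of 24 h, at a dose of 1 mg/kg by the intravenous route (a lower number here means slower removal, a higher number faster removal of the compound), where compound 2 gives 2.6 mL/min/kg, the lowest of three numbers. Compound 1 `Cn1nccc1-c1cc(C(F)(F)F)ccc1[C@H]1CCc2cc(S(=O)(=O)Nc3ncccn3)ccc21` gives 3.3 mL/min/kg, within the scatter of compound 2. Compound 3 `Cn1nccc1-c1cc(C(F)(F)F)ccc1[C@H]1CCOc2cc(S(=O)(=O)Nc3nccs3)ccc21` gives 14 mL/min/kg, beyond the scatter above compound 2; compound 3 differs from compound 2 in more than one place, so its number alone settles nothing about any single change. Compound 4 `O=S(=O)(Nc1nccs1)c1ccc2c(c1)OCC[C@@H]2c1ccc(C(F)(F)F)cc1-c1ccc(F)nc1` has not been measured. It differs from compound 2 in one place: 1,3-thiazol-2-yl in place of pyrimidin-2-yl on a sulfonamide nitrogen. Among the measured compounds shown here, no measured pair shows this change by itself. For the measured compounds named here, compound 3, the only compound carrying the entering group, gives 14 mL/min/kg, so for compound 4 an upward step is expected, a 2.7-fold higher number from compound 2 to compound 4 (0.43 log units; beyond the scatter). Compound 4 is expected to give about 7 mL/min/kg, within 2.5 mL/min/kg to 20 mL/min/kg.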

Compound 4, clearance: 14 mL/min/kg
The estimate for compound 4 lay 2.0-fold (0.30 log units) below the measured number; the measured number falls inside the stated range.
By their numbers in this assay, from the lowest: compounds 2 and 1 (each within the scatter of the next); then compounds 3 and 4 (each within the scatter of the next).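

In this assay the swap of pyrimidin-2-yl for 1,3-thiazol-2-yl on a sulfonamide nitrogen, now seen alone, gives a 5.4-fold higher number from compound 2 to compound 4 (0.73 log units; beyond the scatter) and so is enough by itself to move the number beyond the scatter. The change of 1-methyl-1H-pyrazol-5-yl to 6-fluoropyridin-3-yl on an aromatic carbon gives no change at the digits printed from compound 3 to compound 4 (within the scatter) when the thiazole is present. Nothing shown explains the thiazole step. Still open, going by these compounds, is how a pyridin-2-yl or an acetyl group on that nitrogen would read, and whether the thiazole step holds on the core of compound 1.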